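From acetyl to methoxymethyl on compound 3

The source may hold more compounds than are shown below. What is called first, only, known or untested is meant among the compounds shown, and "the series" means these compounds.

Measured so far in a functional assay on HL-60 cells (Homo sapiens) for antiproliferative activity, read by MTT assay, with a stated time of 48 h; on this read-out lower numbers stand for stronger inhibition and higher numbers for weaker inhibition
compound 1 `COC/C1=C/C[C@](C)(CCC=C(C)C)/C=C/[C@@H](OC(=O)C=C(C)C)[C@](C)(OC)/C=C/C1=O` gives 4050 nM
compound 2 `CC(C)=CCC[C@]1(C)/C=C/[C@@H](OC(=O)C=C(C)C)[C@](C)(O)/C=C/C(=O)/C(COC(=O)c2ccc([N+](=O)[O-])cc2)=C\C1` gives 830 nM
compound 3 `CC(=O)O[C@@H]1/C=C/[C@@](C)(CCC=C(C)C)C/C=C(/CO)C(=O)/C=C/[C@@]1(C)O` gives 5050 nM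

Repeated measurements of this kind scatter somewhat, so small gaps between numbers mean little. Compound 3, at 5050 nM in this assay, is level within that scatter with compound 1. Compound 2 has a lower number, and its gap to compound 3 lies clearly beyond the scatter.

The next compound to be tested is compound 4 `COCO[C@@H]1/C=C/[C@@](C)(CCC=C(C)C)C/C=C(/CO)C(=O)/C=C/[C@@]1(C)O`. It differs from compound 3 in one place: methoxymethyl stands in place of acetyl on an oxygen on a saturated carbon (methoxymethyl in place of acetyl on an oxygen on a saturated carbon).

For the measured compounds named here, no two measured compounds differ in only one place, so nothing here shows directly what this swap does. Compounds 1 and 2 differ from compound 3 in more than one place and cannot isolate it. The plain expectation is therefore no step beyond the scatter in this assay, with only a slight lean towards a higher number. The expected outcome is a 1.2-fold higher number from compound 3 to compound 4 (0.07 log units; within the scatter) and this estimated step stays within the scatter. The estimated value for compound 4 is 6000 nM (expected range 2500 nM to 15000 nM).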

Compound 4, half-maximal inhibitory concentration: > 40000 nM
Compound 4 gave a limit, no number (the forecaster's own chance of this, stated with the estimate: 15%); middle value at least 6.6-fold (0.82 log units) away from the limit.
By their numbers in this assay, from the lowest: compound 2; then compounds 1 and 3 (each within the scatter of the next). At a limit, above all of these: compound 4.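

In this assay, putting methoxymethyl in place of acetyl on an oxygen on a saturated carbon gives an at least 7.9-fold higher number from compound 3 to compound 4 (0.89 log units; beyond the scatter). For the compounds shown here, this is the first change made in one place only, and it shows that activity depends strongly on what sits on this oxygen, even though both groups have the same count of heavy atoms and of hydrogen-bond acceptors and the acetyl alone has a double bond. Compound 4 gives > 40000 nM, which is a limit of the assay and not a number, so the step has a floor but no known full size: the limit of > 40000 nM in this assay, at which 1 of the 4 values shown sits.

Going by these compounds alone, only two groups can be compared directly on this oxygen, so it remains open whether a plain hydroxyl, a methyl ether or a propionyl ester would behave like the acetyl of compound 3 or the methoxymethyl of compound 4. The reason for the loss also stays open, as a single pair of compounds cannot separate the loss of the ester from any other difference between these two groups.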